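A few compounds are considered here, and "the series" means these few. Any claim that something is new, unique, unknown or untested is made for them only; others in the source may bear on it.

Compound 1 `CC(=O)N(CCCCCCN1C[C@H](O)[C@@H](O)[C@H](O)[C@H]1CO)C1CCCCC1` and compound 2 `CC(C)(C)C(=O)N(CCCCCCN1C[C@H](O)[C@@H](O)[C@H](O)[C@H]1CO)c1ccc(F)cc1F` share a core and were both tested in an ADME assay on MDBK cells (Bos taurus) for cytotoxicity, read by MTT assay; on this read-out higher numbers stand for lower toxicity in this test and lower numbers for higher toxicity in this test. In this assay compound 1 reaches only the limit of the test, > 500000 nM. In this assay compound 2 likewise gives only a limit, > 500000 nM. Compound 2 therefore stands at the limit of > 500000 nM in this assay, at which 2 of the 2 values shown sit, so no number separates it from compound 1. Compound 3 `CC(=O)N(CCCCCCN1C[C@H](O)[C@@H](O)[C@H](O)[C@H]1CO)c1ccc(F)cc1F` differs from compound 2 by methyl in place of tert-butyl on a carbonyl carbon. Among the compounds with values here, with no measured step of this kind, compound 3 is expected to remain at the limit, with a step of a number no higher from compound 2 to compound 3 (the limit leaves the size open) inside the scatter. Compound 3 is thus estimated at 500000 nM, between 250000 nM and 1000000 nM.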

Compound 3, half-maximal cytotoxic concentration: > 500000 nM
Compound 3: no number, only a limit (the forecaster's own chance of this, stated with the estimate: 85%); the middle value sits exactly at the limit.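

No step can be read among compound 1, compound 2 and compound 3 in this assay: each gives only a limit of the test, not a number. On these data alone, how far their true values lie past that limit, and whether they differ at all, stays open.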